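Ring Size at the Amino Substituent: Compound 3 to Compound 4

A few compounds are considered here, and "the series" means these few. Any claim that something is new, unique, unknown or untested is made for them only; others in the source may bear on it.

Measured so far in an assay for inhibition of acid-sensing ion channel 3 (Homo sapiens), read by patch clamp, tested at 20 uM; a higher number here means more inhibition at the concentration tested (going by the name of the read-out), a lower number less inhibition:
compound 1, `C=CCNc1nc(N)c(C(=O)N=C(N)N)nc1Cl`, gives 78%
compound 2, `CCCN(C)c1nc(N)c(C(=O)N=C(N)N)nc1Cl`, gives 91%
compound 3, `NC(N)=NC(=O)c1nc(Cl)c(N2CCCC2)nc1N`, gives 84%

All three compounds share one core and differ only in the amino group on one aromatic carbon. Compound 3, with its pyrrolidin-1-yl group, stands second highest of the three numbers in this assay; its nearest neighbour is compound 1, and its gap to compound 2 is also within the scatter, so none of the three can be ranked against the others with confidence.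

Compound 4, `NC(N)=NC(=O)c1nc(Cl)c(N2CCCCC2)nc1N`, is not yet measured. It differs from compound 3 in one place: piperidin-1-yl in place of pyrrolidin-1-yl on an aromatic carbon.

Within the data shown here, two measured steps touch the same position. The step of a number 6 percentage points higher from compound 1 to compound 3 (within the scatter) and the step of a number 7 percentage points lower from compound 2 to compound 3 (within the scatter) both stayed within the scatter, while only a number 13 percentage points higher from compound 1 to compound 2 (beyond the scatter) went beyond it. Replacing one small ring amine by a slightly larger one is therefore expected to give no step beyond the scatter, a number 2 percentage points higher from compound 3 to compound 4 (within the scatter). Compound 4 is estimated at 86% in this assay, with a range from 74% to 96%.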

Compound 4, a percentage reported as inhibition, at one concentration (the size of the read-out at that concentration, not a potency): 85%
Compound 4: middle estimate off by 1 percentage points, on the high side; low and high end bracket the measured number.
By their numbers in this assay, from the lowest: compounds 1, 3, 4 and 2 (each within the scatter of the next, the first and the last beyond it).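

In this assay, going from the pyrrolidin-1-yl ring to the piperidin-1-yl ring gives a number 1 percentage points higher from compound 3 to compound 4 (within the scatter), so this position shows no readable response to this one-carbon change in ring size. The piperidin-1-yl ring also cannot be separated from either open-chain group, with a number 6 percentage points lower from compound 2 to compound 4 (within the scatter) and a number 7 percentage points higher from compound 1 to compound 4 (within the scatter), even though those two groups lie beyond the scatter of each other in a number 13 percentage points higher from compound 1 to compound 2 (beyond the scatter). Nothing available on these compounds bears on what lies behind these numbers.

The compounds shown leave open whether the inhibition in this assay stays level with a seven-membered azepan-1-yl ring, or with a morpholin-4-yl ring, which carries an oxygen atom in place of one ring carbon. Each number also comes from a single tested concentration, so real differences in inhibition at other concentrations between the piperidin-1-yl and pyrrolidin-1-yl compounds remain possible and would need full concentration-response measurements to be seen.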